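The source may hold more compounds than are shown below. What is called first, only, known or untested is meant among the compounds shown, and "the series" means these compounds.

Measured compounds in an ADME assay on HELF cells (Homo sapiens) for cytotoxicity, with a stated time of 3 days; on this read-out higher numbers stand for lower toxicity in this test and lower numbers for higher toxicity in this test:
Compound 1 `CC(C)[C@H](NC(=O)[C@]1(Cc2ccccc2)CCN1C(=O)OCc1ccccc1)C(N)=O` gives > 100000 nM, a limit of the assay rather than a number.
Compound 2 `C[C@H](NC(=O)[C@@]1(Cc2ccccc2)CCN1C(=O)OCc1ccccc1)C(=O)NC(C)(C)C` gives > 100000 nM, again a limit.
Compound 3 `C[C@H](NC(=O)[C@]1(Cc2ccccc2)CCN1S(=O)(=O)c1ccc2ccccc2c1)C(N)=O` gives > 100000 nM, also a limit.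

Compound 2 therefore stands at the limit of > 100000 nM in this assay, at which 3 of the 3 values shown sit, and nothing in the three values shown separates it from the others. Compound 4 `C[C@H](NC(=O)[C@@]1(Cc2ccccc2)CCN1C(=O)OCc1ccccc1)C(=O)NC1CCCCC1` differs from compound 2 by cyclohexyl in place of tert-butyl on an amide-type nitrogen. Within the data shown here, no step between measured compounds is known, so the expectation rests only on the three limits. The step expected here, a number no higher from compound 2 to compound 4 (the limit leaves the size open), is none beyond the usual scatter, with the result most likely to be reported as a limit again. Compound 4 is estimated at 100000 nM, within a range from 50000 nM to 200000 nM.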

Compound 4, minimum cytotoxic concentration: 100000 nM
Compound 4: the middle estimate sits on the measured number at the digits printed; the range from low to high includes it.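

In this assay compound 4 gives 100000 nM, the first value shown that is a number rather than a limit. Cyclohexyl in place of tert-butyl on an amide-type nitrogen gives a number no higher from compound 2 to compound 4 (the limit leaves the size open), so this position has now yielded a reading, though the size of the step cannot be read. The comparison remains anchored to a limit: the limit of > 100000 nM in this assay, at which 3 of the 4 values shown sit.

As far as these compounds go, how a longer alkyl chain, an amine or a carboxylic acid on this amide-type nitrogen would read in this assay remains open.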